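The compounds below may be only part of what the source reports. "The series", "measured", "known", "first", "only" and "open" are said of these compounds alone.

Measured compounds:
- Compound 1, `CN(Cc1ccc(C2=NCCN2)cc1)C(=O)COCCN(C)S(=O)(=O)c1c(Cl)cccc1Cl`: 8.5
- Compound 2, `COc1cc(C)c(S(=O)(=O)N(C)CCOCC(=O)N2CCN(C3CCN(C4CC4)CC3)CC2)c(C)c1`: 8.5
- Compound 3, `COc1cc(C)c(S(=O)(=O)N(C)CCOCC(=O)N2CCN([C@H]3CN4CCC3CC4)CC2)c(C)c1`: 7.2

In a functional assay on Umbilical vein for antagonist activity at B1 bradykinin receptor (Homo sapiens), using Schild analysis, with a stated time of 30 min (on this read-out lower numbers stand for lower potency and higher numbers for higher potency (the scale is a negative logarithm)), compound 1 gives 8.5. Compound 2 gives 8.5, level with compound 1 at the digits shown; together these two are the highest of the three numbers, and the gap between them is within the scatter. Compound 3 gives 7.2, the lowest of the three. Among the measured compounds shown here, the only step between measured compounds differing in one place is a number 1.30 log units lower from compound 2 to compound 3 (beyond the scatter). That step sits on an amine nitrogen in a ring of the core shared by compound 2 and compound 3, a core compound 1 does not have, and it does not touch the sulfonyl sulfur.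

Compound 4, `CN(Cc1ccc(C2=NCCN2)cc1)C(=O)COCCN(C)S(=O)(=O)c1ccc(OC(F)(F)F)cc1`, is not yet measured in this assay. It differs from compound 1 in one place: 4-(trifluoromethoxy)phenyl in place of 2,6-dichlorophenyl on a sulfonyl sulfur. For the measured compounds named here, no measured pair changes the group on the sulfonyl sulfur, so the data give no precedent for the size or direction of this step; the 2>3 step concerns a different position and a different core and does not bear on it. The expectation is therefore held loosely, with a wide range.

For compound 4 a step of a number 0.60 log units lower from compound 1 to compound 4 (beyond the scatter) is expected in this assay, a small loss that may fall within the scatter. The estimate for compound 4 is 7.9, with a range from 6.9 to 8.9.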

Compound 4, negative logarithm of the antagonist equilibrium constant: 7.5
Compound 4: the middle estimate sits 0.40 log units above what was measured; the range from low to high includes it.
By their numbers in this assay, from the lowest: compounds 3 and 4 (each within the scatter of the next); then compounds 1 and 2 (each within the scatter of the next).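

In this assay, the group on a sulfonyl sulfur proves to be a position where potency responds: 4-(trifluoromethoxy)phenyl in place of 2,6-dichlorophenyl gives a number 1.00 log units lower from compound 1 to compound 4 (beyond the scatter). The shared core stays the same and both groups keep one six-membered aromatic ring of carbon only with no net charge, so a change in what the ring carries is enough to produce a step of this size, though compound 4 still reads 7.5. Nothing measured here bears on why the step occurs.

This single step removes the two chlorines and adds the trifluoromethoxy group at once, so it cannot say which part carries the loss; an unsubstituted phenyl or a phenyl bearing one chlorine would separate the two contributions. Also open, from the compounds shown here alone, is whether the same swap would give a similar step on the core of compound 2, and how a non-aromatic group, such as cyclohexyl, or a longer chain would fare on a sulfonyl sulfur.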